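Methyl to trifluoromethyl on the pyrazole of compound 3

This account rests on a few compounds, and the source may have more. Where it says the series, first, only, none or still open, it means among the compounds named here.

Measured compounds in a functional assay on HFL1 cells for antagonist activity at sphingosine 1-phosphate receptor 2 (Homo sapiens), read by ELISA, with a stated time of 24 h, in the absence of a further agent; a higher number here means a weaker inhibitor, a lower number a stronger inhibitor:
compound 1 `Cc1cc(CNC(=O)c2cc3c(Cl)cc(Cl)cc3[nH]2)ncc1-c1cn(C)nc1C`, 0.61 nM
compound 2 `Cc1cc(CNC(=O)Nc2cc(Cl)nc(Cl)c2)ncc1-c1cn(C)nc1C`, 0.77 nM
compound 3 `CCOc1cc(NC(=O)NCc2cc(C)c(-c3cn(C)nc3C)cn2)cc(Cl)n1`, 0.032 nM

Compound 3 gives the lowest number of the three, and its separation from compound 1 and from compound 2 lies beyond the scatter in each case. Among the compounds with values here, the one single-point step among the measured compounds is a 24-fold lower number from compound 2 to compound 3 (1.38 log units; beyond the scatter), an ethoxy in place of chloro on an aromatic carbon of the core of compound 2.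

Compound 4 `CCOc1cc(NC(=O)NCc2cc(C)c(-c3cn(C)nc3C(F)(F)F)cn2)cc(Cl)n1` differs from compound 3 by trifluoromethyl in place of methyl on an aromatic carbon. Within the data shown here, this change sits on the 1,3-dimethyl-1H-pyrazol-4-yl group, which is held unchanged across compounds 1, 2 and 3, so no measured step bears on it; the step from compound 2 to compound 3 concerns a different part of the molecule. With nothing to weigh either way, the expected step from compound 3 to compound 4 in this assay is small, a 1.4-fold higher number from compound 3 to compound 4 (0.15 log units; within the scatter), and within the scatter. Compound 4 is therefore estimated at 0.045 nM, with a range from 0.01 nM to 0.25 nM.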

Compound 4, half-maximal inhibitory concentration: 22 nM
Beside the measured number, compound 4's estimate is 490-fold (2.69 log units) below it; measured number above the stated range.
By their numbers in this assay, from the lowest: compound 3; then compounds 1 and 2 (each within the scatter of the next); then compound 4.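

Within the data shown here, until now the 1,3-dimethyl-1H-pyrazol-4-yl group had been constant, so compound 4 gives the first reading of this aromatic carbon next to the ring nitrogen. In this assay, among these compounds, trifluoromethyl in place of methyl gives a 690-fold higher number from compound 3 to compound 4 (2.84 log units; beyond the scatter), showing that this single change at this position can move the number a long way, and in the opposite direction to the one earlier step. Nothing available explains why the number rises so far.

The compounds shown leave open how an ethyl, a cyclopropyl or a chloro on this carbon would read, and so whether the loss is particular to trifluoromethyl. They also leave open whether the same change would cost as much with the other parts of compound 1 or compound 2 in place.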